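This account rests on a few compounds, and the source may have more. Where it says the series, first, only, none or still open, it means among the compounds named here.

Compound 3, `CNCCNc1nnc(-c2ccccc2)cc1C`, gives >= 30 mg/kg in a functional assay on the whole organism for positive allosteric modulation, with Mus musculus as the target (on this read-out higher numbers stand for an effect only at larger amounts of compound and lower numbers for an effect already at smaller amounts), and this is a limit, not a number. Compound 1, `Cc1cc(-c2ccccc2)nnc1NCCN`, gives > 30 mg/kg in this assay, also a limit. Compound 2, `Cc1cc(-c2ccccc2)nnc1NCCCCN`, gives > 30 mg/kg in this assay, again a limit. Going by the values given here, every value so far therefore sits at a limit: the limit of > 30 mg/kg in this assay, at which 2 of the 3 values shown sit, and (the limit of >= 30 mg/kg in this assay, at which 1 of the 3 values shown sits).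

Compound 4, `CCCN(CCC)CCNc1nnc(-c2ccccc2)cc1C`, carries dipropylamino in place of methylamino on a saturated chain carbon, two bonds along the chain from a nitrogen on an aromatic ring.

The closest measured change is a step that the two limits leave unreadable from compound 1 to compound 3, which puts methyl in place of hydrogen on an amine nitrogen. The others are a step that the two limits leave unreadable from compound 1 to compound 2 and a step that the two limits leave unreadable from compound 2 to compound 3. None of them gives a size or a direction.

Compound 3 offers only its limit of >= 30 mg/kg as a starting point, so no step beyond the scatter is expected in this assay. The expected step is a number no higher from compound 3 to compound 4 (the limit leaves the size open). For compound 4 the estimated value is 30 mg/kg, with an expected range from 10 mg/kg to 100 mg/kg.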

Compound 4, dose for half-maximal effect: > 30 mg/kg
Compound 4 was reported as a limit; the forecaster's own chance of this, stated with the estimate: 65%; the middle value lies on the limit itself.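

The steps from compound 1, compound 2 and compound 3 to compound 4 cannot be read in this assay; all four compounds are reported only as limits. The compounds shown leave open whether any of these changes shifts the dose for half-maximal effect, and in which direction.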